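A further methoxy on compound 2: expectation

A few compounds are considered here, and "the series" means these few. Any claim that something is new, unique, unknown or untested is made for them only; others in the source may bear on it.

Compound 1 `Nc1ccc(C(=O)/C=C/c2ccccc2)cc1` gives 14000 nM in a functional assay on L1210 cells (Mus musculus) for antiproliferative activity, with a stated time of 48 h; a lower number here means a stronger inhibitor, a higher number a weaker inhibitor. Going by the values given here, compound 2 `COc1cccc(/C=C/C(=O)c2ccc(N)cc2)c1` gives 22000 nM in this assay and stands at the higher end of the two numbers so far, within the scatter of compound 1. Among the compounds with values here, the only measured step, a 1.6-fold higher number from compound 1 to compound 2 (0.20 log units; within the scatter), lies within the scatter. Compound 3 `COc1cccc(/C=C/C(=O)c2ccc(N)cc2)c1OC` differs from compound 2 by methoxy in place of hydrogen on an aromatic carbon. Within the data shown here, the one step that bears on this change is a 1.6-fold higher number from compound 1 to compound 2 (0.20 log units; within the scatter), so nothing beyond the scatter is expected here. The expected step is a 1.1-fold higher number from compound 2 to compound 3 (0.06 log units; within the scatter). Compound 3 is therefore estimated at 25000 nM, with a range of 10000 nM to 60000 nM.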

Compound 3, half-maximal inhibitory concentration: 13000 nM
Estimate against measurement, compound 3: 1.9-fold (0.28 log units) above, within the range that was stated.
By their numbers in this assay, from the lowest: compounds 3, 1 and 2 (each within the scatter of the next).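

In this assay, methoxy in place of hydrogen on this aromatic carbon, ortho to a large group and ortho to a methoxy group, gives a 1.7-fold lower number from compound 2 to compound 3 (0.23 log units; within the scatter). A second methoxy on this ring of the shared core is therefore accommodated at this position without a step beyond the scatter. Nothing measured here speaks to the reason for this result.

Still open, from the compounds shown here alone, is whether a different group at this position, such as an ethoxy, an amine or a carboxylic acid, would move the number beyond the scatter.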